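The source may hold more compounds than are shown below. What is called first, only, known or untested is meant among the compounds shown, and "the series" means these compounds.

Measured so far in a functional assay on PC-3 cells (Homo sapiens) for cytotoxicity, read by sulforhodamine B assay; on this read-out lower numbers stand for higher toxicity in this test and higher numbers for lower toxicity in this test:
- compound 1 `COc1cccc(OC)c1OCCNCCOc1ccccc1OCc1ccccc1Cl`: 58900 nM
- compound 2 `COc1cccc(OC)c1OCCNCCOc1ccccc1OCc1cccc(C)c1`: 87100 nM
- compound 3 `COc1cccc(OC)c1OCCNCCOc1ccccc1OCc1ccc(C)cc1`: 61700 nM

Compound 3 holds the second highest of the three numbers, with compound 1 nearest and compound 2 furthest, and both gaps within the scatter. Compound 4 `COc1cccc(COc2ccccc2OCCNCCOc2c(OC)cccc2OC)c1` arises from compound 3 by 3-methoxyphenyl in place of 4-methylphenyl on a saturated chain carbon bound to an oxygen on an aromatic ring. The two steps that bear on this are the earlier exchanges at the same place: a 1.0-fold higher number from compound 1 to compound 3 (0.02 log units; within the scatter) and a 1.4-fold lower number from compound 2 to compound 3 (0.15 log units; within the scatter). Neither moved this assay beyond the scatter, and nothing measured here separates a methoxy from a methyl on that aromatic ring. The step is therefore expected to stay flat, a 1.1-fold higher number from compound 3 to compound 4 (0.02 log units; within the scatter), with compound 4 estimated at 65000 nM, between 30000 nM and 140000 nM.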

Compound 4, concentration lethal to 50% of the cells: 61700 nM
Beside the measured number, compound 4's estimate is 1.1-fold (0.02 log units) above it; low and high end bracket the measured number.
By their numbers in this assay, from the lowest: compounds 1, 3, 4 and 2 (each within the scatter of the next).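

In this assay, 3-methoxyphenyl in place of 4-methylphenyl on a saturated chain carbon bound to an oxygen on an aromatic ring gives no change at the digits printed from compound 3 to compound 4 (within the scatter), so the position tolerates this exchange, which adds a hydrogen-bond acceptor, with no shift beyond the scatter. Methoxy in place of methyl on an aromatic carbon gives a 1.4-fold lower number from compound 2 to compound 4 (0.15 log units; within the scatter), and 3-methoxyphenyl in place of 2-chlorophenyl gives a 1.0-fold higher number from compound 1 to compound 4 (0.02 log units; within the scatter), so methoxy, methyl and chloro variants remain unseparated here. No supporting data bear on this flat result.

From the compounds shown here alone, whether an amine or a carboxylic acid on that aromatic ring would leave the scatter remains open. So does the effect of a longer chain at this place.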